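Oxy to sulfanyl swap in a weakly cytotoxic series

The source may hold more compounds than are shown below. What is called first, only, known or untested is meant among the compounds shown, and "the series" means these compounds.

Compound 1 `Cc1cc(C)nc(Oc2ccc(NC(=O)Nc3ccc(OC(F)(F)F)cc3)cc2)n1` is tested in a functional assay on MCF7 cells (Homo sapiens) for cytotoxicity, read by MTT assay, with a stated time of 3 days; a lower number here means a stronger inhibitor, a higher number a weaker inhibitor. In this assay compound 1 gives > 50000 nM, which is a limit of the assay rather than a number. Compound 2 `Cc1cc(C)nc(Oc2ccc(NC(=O)Nc3ccc(F)cc3)cc2)n1` carries the change (fluoro in place of trifluoromethoxy on an aromatic carbon). In this assay compound 2 gives > 50000 nM, again a limit and not a number. The step that the two limits leave unreadable from compound 1 to compound 2 therefore cannot be read, because both values sit at the limit of > 50000 nM in this assay, at which 2 of the 3 values shown sit. Compound 3 `Cc1cc(C)nc(Sc2ccc(NC(=O)Nc3ccc(OC(F)(F)F)cc3)cc2)n1` differs from compound 1 by (4,6-dimethylpyrimidin-2-yl)sulfanyl in place of (4,6-dimethylpyrimidin-2-yl)oxy on an aromatic carbon. In this assay, within the data shown here, compound 3 gives 41700 nM, the only number in the set, and the step of an at least 1.1-fold lower number from compound 1 to compound 3 (0.07 log units; that floor lies within the scatter) is the one readable step.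

Compound 4 `Cc1cc(C)nc(Sc2ccc(NC(=O)Nc3ccc(F)cc3)cc2)n1` has not yet been measured in this assay. It differs from compound 3 by fluoro in place of trifluoromethoxy on an aromatic carbon, the same change made from compound 1 to compound 2, with the same surroundings at the place of change. That earlier step is unreadable, so it gives no direction for the present one. Among the measured compounds shown here, the step from compound 3 to compound 4 is expected to be a 1.4-fold higher number from compound 3 to compound 4 (0.16 log units; within the scatter), resting on compound 3 at 41700 nM as the one number measured in the set. Compound 1 and compound 2 both sit at the limit of > 50000 nM in this assay, at which 2 of the 3 values shown sit. Compound 4 is expected to give about 60000 nM in this assay. The expected range for compound 4 runs from 25000 nM to 150000 nM, with a fair chance that only a limit is reported.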

Compound 4, half-maximal inhibitory concentration: > 50000 nM
Compound 4: a limit, no number; the forecaster's own chance of this, stated with the estimate: 60%; the middle value does not contradict the limit.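

In this assay the change from trifluoromethoxy to fluoro on the core of compound 3 gives an at least 1.1-fold higher number from compound 3 to compound 4 (0.07 log units; that floor lies within the scatter) and so offers no direction for the change on this core. In this assay compound 4 gives > 50000 nM as a limit of the assay and not a number. The same change on the core of compound 1 cannot be read, so the series shows neither that the change carries from one core to the other nor that it fails to carry, since nearly all values stop at the same ceiling: the limit of > 50000 nM in this assay, at which 3 of the 4 values shown sit.

Open, as far as these compounds go, is whether an amine, a carboxylic acid or a longer chain in place of the trifluoromethoxy or fluoro group would bring values down from that ceiling to numbers that can be compared across both cores. Also open, from the compounds shown here alone, is whether the swap of (4,6-dimethylpyrimidin-2-yl)oxy for (4,6-dimethylpyrimidin-2-yl)sulfanyl has any readable size when fluoro is the group present, as compound 2 and compound 4 both stand only as limits.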